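Fluoro on the N-aryl ring: compound 2 to compound 3

This account rests on a few compounds, and the source may have more. Where it says the series, first, only, none or still open, it means among the compounds named here.

Measured so far:
compound 1, `O=C(Nc1ccc(Oc2ccnc3[nH]ccc23)c(F)c1)c1cc2cccnc2n(-c2ccc(F)cc2)c1=O`: 620 nM
compound 2, `Cn1ccc2c(Oc3ccc(NC(=O)c4cc5cccnc5n(-c5ccccc5)c4=O)cc3F)ccnc21`: 3590 nM

Among the measured compounds shown here, in a functional assay on U-87MG ATCC cells for antiproliferative activity against U-87 MG (Homo sapiens), read by MTT assay, with a stated time of 72 h (a lower number here means a stronger inhibitor, a higher number a weaker inhibitor), compound 2 gives 3590 nM, the highest of the two numbers so far. Its nearest neighbour is compound 1, which in this assay gives 620 nM, a lower number, and the gap between these two lies beyond the scatter. For the measured compounds named here, no single-change step between measured compounds is available; compound 1 and compound 2 differ in more than one place, so their two values say only that the pair sits well apart.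

Compound 3, `Cn1ccc2c(Oc3ccc(NC(=O)c4cc5cccnc5n(-c5ccc(F)cc5)c4=O)cc3F)ccnc21`, differs from compound 2 by fluoro in place of hydrogen on an aromatic carbon, that is phenyl to 4-fluorophenyl. With no measured step of this kind in the set, the expectation is a modest move toward a lower number, of a size near the scatter rather than clearly beyond it, as a 2.0-fold lower number from compound 2 to compound 3 (0.30 log units; within the scatter). Compound 3 is therefore estimated at 1800 nM, within 600 nM to 5400 nM.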

Compound 3, half-maximal inhibitory concentration: 1320 nM
For compound 3 the middle estimate is 1.4-fold (0.13 log units) above the measured one; measured number inside the range.
By their numbers in this assay, from the lowest: compound 1; then compound 3; then compound 2.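

In this assay, among the compounds shown here, the change from phenyl to 4-fluorophenyl gives a 2.7-fold lower number from compound 2 to compound 3 (0.43 log units; beyond the scatter), the first single-place reading at this position, and it is a modest gain. Compound 3 also connects the other two compounds: methyl in place of hydrogen on an aromatic nitrogen gives a 2.1-fold higher number from compound 1 to compound 3 (0.33 log units; beyond the scatter), so the wide separation of compound 1 and compound 2 resolves into two modest single-place steps. No available data bear on what lies behind either step.

On these data alone, what chloro, methoxy or an amine on the same aromatic carbon would do remains open, as does the effect of ethyl or a longer chain on the aromatic nitrogen. Also open is whether the fluoro step holds with hydrogen on that nitrogen, since the compounds shown give this step only with methyl there.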